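Swapping a fluorophenyl arm for a nitrile on the pyrazole acid

The compounds below may be only part of what the source reports. "The series", "measured", "known", "first", "only" and "open" are said of these compounds alone.

Measured compounds:
- compound 1, `Cc1n[nH]c(C(=O)O)c1Cc1ccc2ccccc2n1`: 1700 nM
- compound 2, `Cc1n[nH]c(C(=O)O)c1Cc1cccc(-c2ccccc2F)c1`: 900 nM

In an assay on isolated protein for inhibition of 2-Hydroxyacid oxidase 2 (Rattus norvegicus) (on this read-out higher numbers stand for weaker inhibition and lower numbers for stronger inhibition), compound 1 gives 1700 nM, and in this assay compound 2 gives 900 nM. Compound 2 stands at the lower of the two numbers, but its gap to compound 1 lies within the scatter of repeated measurements, so the two cannot be told apart.

Compound 3, `Cc1n[nH]c(C(=O)O)c1Cc1cccc(C#N)c1`, has not yet been measured. Its change from compound 2 is cyano in place of 2-fluorophenyl on an aromatic carbon. For the measured compounds named here, no step between measured compounds covers a change of this kind, so the expectation rests only on the loss of a sizeable group from compound 2, whose value is 900 nM. Compound 3 is expected to give a weaker result, a step of a 4.4-fold higher number from compound 2 to compound 3 (0.65 log units; beyond the scatter) beyond the scatter. The estimate for compound 3 is 4000 nM, with a range from 1000 nM to 15000 nM.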

Compound 3, half-maximal inhibitory concentration: 500 nM
Estimate against measurement, compound 3: 8.0-fold (0.90 log units) above; the whole stated range lies above it.
By their numbers in this assay, from the lowest: compounds 3, 2 and 1 (each within the scatter of the next, the first and the last beyond it).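

In this assay, putting cyano in place of 2-fluorophenyl on this aromatic carbon gives a 1.8-fold lower number from compound 2 to compound 3 (0.26 log units; within the scatter), so the two groups cannot be told apart. For this pair, then, the six-membered aromatic ring of the 2-fluorophenyl arm is not needed to keep the read-out at this level, and a far smaller group with no ring, cyano, serves equally well at this position. Nothing available here accounts for why two such different groups read alike.

As far as these compounds go, whether a bare hydrogen, an amine or a primary amide on the same aromatic carbon would stay level with these two groups or separate from them remains open. So does whether cyano would read the same on another carbon of this ring.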